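The compounds below may be only part of what the source reports. "The series", "measured", "known", "first", "only" and "open" are said of these compounds alone.

In a functional assay (muscle tissue) with Cavia porcellus as the target (a higher number here means that more compound is needed for the effect, a lower number that less compound is needed), three compounds with a shared core differ only in the aryl group on a saturated ring carbon. Compound 1 `COC(=O)C1=C(C)N=C(C)/C(=C(\O)OC)C1c1cc(Cl)cc(Cl)c1`, with 3,5-dichlorophenyl, gives 93.3 nM. Compound 2 `COC(=O)C1=C(C)N=C(C)/C(=C(\O)OC)C1c1ccccc1Cl`, with 2-chlorophenyl, gives 2.19 nM. Compound 3 `COC(=O)C1=C(C)N=C(C)/C(=C(\O)OC)C1c1c(Cl)cccc1Cl`, with 2,6-dichlorophenyl, gives 1.91 nM, which puts it at the low end of the set, level with compound 2 (a 1.1-fold lower number from compound 2 to compound 3 (0.06 log units; within the scatter)). Compound 4 `COC(=O)C1=C(C)N=C(C)/C(=C(\O)OC)C1c1ccc(C#N)cc1` carries a new aryl group: 4-cyanophenyl in place of 2,6-dichlorophenyl on a saturated ring carbon. For the measured compounds named here, no measured compound has a 4-cyanophenyl group, so the evidence is indirect. The nearest guide is a 49-fold lower number from compound 1 to compound 3 (1.69 log units; beyond the scatter), supported by a 43-fold lower number from compound 1 to compound 2 (1.63 log units; beyond the scatter): both show that the aryl group can move the number a long way. Compound 4, like compound 1, lacks the 2-chlorophenyl and 2,6-dichlorophenyl groups of the two low compounds, so a large rise in this assay is expected, of about that size or somewhat more. The expected change is a 160-fold higher number from compound 3 to compound 4 (2.20 log units; beyond the scatter). The estimate for compound 4 is 300 nM, with an expected range of 40 nM to 2500 nM.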

Compound 4, half-maximal effective concentration: 3470 nM
Beside the measured number, compound 4's estimate is 12-fold (1.06 log units) below it, outside the stated range (above it).
By their numbers in this assay, from the lowest: compounds 3 and 2 (each within the scatter of the next); then compound 1; then compound 4.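

In this assay, for the compounds shown here, the aryl group on this saturated ring carbon spans far more than the earlier compounds showed, with a 1800-fold higher number from compound 3 to compound 4 (3.26 log units; beyond the scatter) and a 1600-fold higher number from compound 2 to compound 4 (3.20 log units; beyond the scatter) setting the new width of the set. Compound 1 no longer marks the high end: a 37-fold higher number from compound 1 to compound 4 (1.57 log units; beyond the scatter) shows that lacking the 2-chlorophenyl and 2,6-dichlorophenyl groups does not fix a single level, since the two compounds without them lie far apart. Nothing among the data given explains the size of these steps.

On these data alone, how a 2-cyanophenyl or a 4-chlorophenyl group would stand in this assay remains open. So does the question of whether the nitrile itself or its place on the phenyl ring matters more for the number.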